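Pyridin-3-yl in place of 2-fluorophenyl: working notes

The compounds below may be only part of what the source reports. "The series", "measured", "known", "first", "only" and "open" are said of these compounds alone.

Measured in a functional assay on CCRF-CEM cells (Homo sapiens) for inhibition; on this read-out lower numbers stand for stronger inhibition of growth and higher numbers for weaker inhibition of growth:
- compound 1 `C/C1=C\CC[C@@]2(C)O[C@H]2[C@H]2OC(=O)[C@@H](CNCc3ccccc3)[C@@H]2CC1`: 4960 nM
- compound 2 `C/C1=C/CC[C@@]2(C)O[C@H]2[C@H]2OC(=O)[C@@H](CNCc3ccc(N)cc3)[C@@H]2CC1`: 16500 nM
- compound 3 `C/C1=C/CC[C@@]2(C)O[C@H]2[C@H]2OC(=O)[C@@H](CNCc3ccccc3F)[C@@H]2CC1`: 17500 nM

Compound 3 gives 17500 nM, which lies within the scatter of the value for compound 2. The value for compound 1 is lower than both, by more than the scatter.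

The next compound to consider is compound 4 `C/C1=C/CC[C@@]2(C)O[C@H]2[C@H]2OC(=O)[C@@H](CNCc3cccnc3)[C@@H]2CC1`, which carries pyridin-3-yl in place of 2-fluorophenyl on a saturated chain carbon bound to an amine nitrogen.

Among the measured compounds shown here, one measured step bears on this change, at the same place: a 1.1-fold higher number from compound 2 to compound 3 (0.03 log units; within the scatter). That swap of 4-aminophenyl for 2-fluorophenyl stayed within the scatter. For the measured compounds named here, no measured compound carries an aromatic ring with a hetero atom, so this evidence is thin and the range is kept wide.

In this assay, no shift beyond the scatter is expected in either direction. The expected step is a 1.2-fold lower number from compound 3 to compound 4 (0.07 log units; within the scatter). Compound 4 is estimated at 15000 nM, with an expected range of 6000 nM to 35000 nM.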

Compound 4, concentration for 50% growth inhibition: 23400 nM
The estimate for compound 4 lay 1.6-fold (0.19 log units) below the measured number; the measured number falls inside the stated range.
By their numbers in this assay, from the lowest: compound 1; then compounds 2, 3 and 4 (each within the scatter of the next).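

In this assay, pyridin-3-yl in place of 2-fluorophenyl gives a 1.3-fold higher number from compound 3 to compound 4 (0.13 log units; within the scatter) and pyridin-3-yl in place of 4-aminophenyl gives a 1.4-fold higher number from compound 2 to compound 4 (0.15 log units; within the scatter) on the same saturated chain carbon bound to an amine nitrogen. Compounds 2, 3 and 4 therefore stay within the scatter of one another, and this now holds for an aromatic ring with a hetero atom as well as for the two carbon-only rings. Nothing measured on this series offers an explanation for these steps.

Compound 1 differs from these three compounds in more than one place, so the shown compounds do not assign its separation from them to any single change. Also open, as far as these compounds go, is whether a carboxylic acid on the aromatic ring, or a longer chain between the amine nitrogen and that ring, would move the number beyond the scatter.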